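Compound 3: a smaller pyrazolyl group at the same place

The source may hold more compounds than are shown below. What is called first, only, known or untested is meant among the compounds shown, and "the series" means these compounds.

- compound 1 `CNCCNCc1cccc(-c2nc(NC3CCOCC3)c(C)c(-c3ccnc4[nH]ccc34)n2)c1` gives 25200 nM as a measured number
- compound 2 `CNCCNCc1cccc(-c2nc(NC3CCOCC3)c(C)c(-c3c(C)nn(C)c3C)n2)c1` gives > 50000 nM as a limit
- compound 3 `CNCCNCc1cccc(-c2nc(NC3CCOCC3)c(C)c(-c3ccnn3C)n2)c1` is not yet measured

In a functional assay on BT-549 cells (Homo sapiens) for inhibition, read by sulforhodamine B assay, with a stated time of 6 days (on this read-out higher numbers stand for weaker inhibition and lower numbers for stronger inhibition), compound 2 gives > 50000 nM, which is a limit and not a number. The standing of compound 2 is thus the limit of > 50000 nM in this assay, at which 1 of the 2 values shown sits, and nothing finer.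

The next change is 1-methyl-1H-pyrazol-5-yl in place of 1,3,5-trimethyl-1H-pyrazol-4-yl on an aromatic carbon. For the measured compounds named here, one measured step bears on this place: an at least 1.9-fold higher number from compound 1 to compound 2 (0.29 log units; that floor lies within the scatter), and it involves a different incoming group. With so little to go on, no step beyond the scatter is expected in this assay, and no direction is favoured. Compound 3 is expected at 45000 nM (estimated range 18000 nM to 90000 nM). The estimate amounts to an at least 1.1-fold lower number from compound 2 to compound 3 (0.04 log units; that floor lies within the scatter). A limit rather than a number may well be expected for compound 3.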

Compound 3, half-maximal inhibitory concentration: > 50000 nM
Compound 3 was reported as a limit (the forecaster's own chance of this, stated with the estimate: 55%); middle value at least 1.1-fold (0.04 log units) away from the limit.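

In this assay compound 3 gives > 50000 nM, which is a limit and not a number. The step between the two pyrazolyl compounds cannot be read, as both ends are limits, so 1-methyl-1H-pyrazol-5-yl and 1,3,5-trimethyl-1H-pyrazol-4-yl cannot be ranked at this place on the shared core. Against the group of compound 1, the smaller pyrazolyl gives an at least 1.9-fold higher number from compound 1 to compound 3 (0.29 log units; that floor lies within the scatter), so a second pyrazolyl group now ends at the same limit, though that floor does not establish a real loss, and the series stands at: the limit of > 50000 nM in this assay, at which 2 of the 3 values shown sit.

Open, from the compounds shown here alone, is whether an amine or a carboxylic acid carried on the group at this place would give a measured number in this assay rather than a limit. Also open, going by these compounds, is how far any pyrazolyl group truly lies from the group of compound 1.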